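Methoxy in Place of Methyl on the Pendant Aryl

A few compounds are considered here, and "the series" means these few. Any claim that something is new, unique, unknown or untested is made for them only; others in the source may bear on it.

Three compounds sharing one core differ only in the aryl group at the end of the ethyl chain. Compound 1 `CCn1nc(C)c2c1CCN(C(C(=O)NC)c1ccccc1)C2CCc1ccc(Cl)cc1` gives 12 nM in a functional assay on CHO cells for antagonist activity at Orexin receptor type 2 (Homo sapiens), read by FLIPR and calcium flux; a lower number here means a stronger inhibitor, a higher number a weaker inhibitor. Compound 2 `CCn1nc(C)c2c1CCN(C(C(=O)NC)c1ccccc1)C2CCc1cccc(C(F)(F)F)c1` gives 7 nM in this assay, and compound 3 `CCn1nc(C)c2c1CCN(C(C(=O)NC)c1ccccc1)C2CCc1ccc(C)cc1` gives 6 nM in this assay. Compound 3 has the lowest of the three numbers, but its separation from the others is small: a 2.0-fold lower number from compound 1 to compound 3 (0.30 log units; within the scatter) and a 1.2-fold lower number from compound 2 to compound 3 (0.07 log units; within the scatter), so no order among the three can be claimed.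

Compound 4 `CCn1nc(C)c2c1CCN(C(C(=O)NC)c1ccccc1)C2CCc1ccc(OC)cc1` carries methoxy in place of methyl on an aromatic carbon. Within the data shown here, no measured step involves a methoxy group, so there is no direct precedent for this change. Among the measured compounds shown here, the steps that bear on it are those that exchange substituents on the same aryl ring: a 2.0-fold lower number from compound 1 to compound 3 (0.30 log units; within the scatter), a 1.7-fold lower number from compound 1 to compound 2 (0.23 log units; within the scatter) and a 1.2-fold lower number from compound 2 to compound 3 (0.07 log units; within the scatter), all within the scatter. Across chloro, trifluoromethyl and methyl this position has shown little movement in this assay. On that basis the step of a 1.3-fold higher number from compound 3 to compound 4 (0.12 log units; within the scatter) is expected to stay within the scatter, with no direction to be inferred. Compound 4 is therefore estimated at 8 nM in this assay, with a range from 3 nM to 20 nM.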

Compound 4, half-maximal inhibitory concentration: 219 nM
The estimate for compound 4 lay 27-fold (1.44 log units) below the measured number; the whole stated range lies below it.
By their numbers in this assay, from the lowest: compounds 3, 2 and 1 (each within the scatter of the next); then compound 4.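

Among these compounds, the aryl position at the end of the chain is not as permissive as the earlier compounds suggested. In this assay, methoxy in place of methyl gives a 37-fold higher number from compound 3 to compound 4 (1.56 log units; beyond the scatter), methoxy in place of chloro gives an 18-fold higher number from compound 1 to compound 4 (1.26 log units; beyond the scatter), and the change from 3-(trifluoromethyl)phenyl to 4-methoxyphenyl gives a 31-fold higher number from compound 2 to compound 4 (1.50 log units; beyond the scatter). Compounds 1, 2 and 3 remain within the scatter of one another, so the tolerance seen earlier holds for chloro, trifluoromethyl and methyl but does not extend to methoxy, the only one of these four substituents that carries an oxygen. Nothing available here accounts for this large step, so the link to the oxygen remains an observation about these compounds and not an explanation.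

The compounds shown leave open whether the step follows the oxygen itself or the larger substituent: an ethyl group in this place, which has no oxygen, would help separate the two. They also leave open how a hydroxyl group, an ethoxy group or an amine on the same aryl carbon would read in this assay.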